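A few compounds are considered here, and "the series" means these few. Any claim that something is new, unique, unknown or untested is made for them only; others in the source may bear on it.

Measured so far in a functional assay on HL-60 cells (Homo sapiens) for antiproliferative activity, read by MTT assay; on this read-out lower numbers stand for stronger inhibition and higher numbers for weaker inhibition:
Compound 1 `O[C@@H]1[C@@H](O)[C@H](Cc2ccccc2)O[C@H](COCc2ccccc2)[C@H]1O` gives "not active" (no number reported)
Compound 2 `OC[C@H]1O[C@@H](Cc2ccccc2)[C@H](O)[C@@H](OCc2ccccc2)[C@@H]1OCc1ccccc1` gives 20200 nM
Compound 3 `OC[C@H]1O[C@@H](Cc2ccccc2)[C@H](O)[C@@H](OCc2ccccc2)[C@@H]1O` gives "not active" (no number reported)

Compound 3 has no single number to place on a scale: compound 3 is reported as "not active" (no number reported) and shares that result with compound 1, while only compound 2 gives a number. Next comes compound 4 `OC[C@H]1O[C@@H](Cc2ccccc2)[C@H](O)[C@@H](O)[C@@H]1O` and the change is hydrogen in place of benzyl on an oxygen on a saturated carbon (hydrogen in place of benzyl on an oxygen on a saturated carbon, or benzyloxy to hydroxy). For the measured compounds named here, no measured pair here shows what this change does on its own. Still, compound 2, with 20200 nM as the only numbered result, carries more benzyloxy groups than compound 3, and compound 4 keeps none. In this assay no gain in strength is therefore expected: the likely outcome is that compound 4 stays inactive, or gives a number weaker than that of compound 2. If a number appears, compound 4 is estimated at 100000 nM with an expected range of 30000 nM to 300000 nM as its span.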

Compound 4, half-maximal inhibitory concentration: "not active" (no number reported)
For compound 4 the study gives words and no number, so the estimate cannot be set against anything.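

In this assay compound 3 and compound 4 are both reported as not active, without a number, so no step can be read between them, and nothing available accounts for this result. From the compounds shown here alone, whether benzyloxy to hydroxy changes antiproliferative strength on its own stays open.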